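A repeated thiophene swap and the step it should make

The source may hold more compounds than are shown below. What is called first, only, known or untested is meant among the compounds shown, and "the series" means these compounds.

Compound 1, `Cc1ccsc1-c1cc(-c2ccco2)cc(-c2ccc(Cl)cc2)n1`, gives 20700 nM.
Compound 2, `Clc1ccc(-c2cc(-c3ccco3)cc(-c3ccc(Cl)s3)n2)cc1`, gives 10500 nM.
Compound 3, `Cc1ccsc1-c1cc(-c2ccc(Cl)o2)cc(-c2ccco2)n1`, gives 10600 nM.

All three were tested in a functional assay on K562 cells (Homo sapiens) for cytotoxicity, read by ELISA, with a stated time of 4 days; a higher number here means a weaker inhibitor, a lower number a stronger inhibitor. Between compound 1 and compound 2 the change is 5-chlorothiophen-2-yl in place of 3-methylthiophen-2-yl on an aromatic carbon, and that change made a 2.0-fold lower number from compound 1 to compound 2 (0.29 log units; within the scatter). Compound 3 carries the same 3-methylthiophen-2-yl group as compound 1, but the difference between the two cores is not broken down here. Its value sits within the scatter of both compound 1 and compound 2, so the three measured numbers cannot be ordered.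

Compound 4, `Clc1ccc(-c2cc(-c3ccco3)nc(-c3ccc(Cl)s3)c2)o1`, has not been measured. It differs from compound 3 by 5-chlorothiophen-2-yl in place of 3-methylthiophen-2-yl on an aromatic carbon. This is the same kind of change as that from compound 1 to compound 2, with one difference around the place: in compound 1 the carbon is meta to a 4-chlorophenyl group (7 heavy atoms), while in compound 3 it is meta to a 5-chlorofuran-2-yl group (6 heavy atoms); in both the carbon is next to the ring nitrogen and meta to a furan-2-yl group (5 heavy atoms).

The step from compound 3 to compound 4 is expected to be a 1.8-fold lower number from compound 3 to compound 4 (0.25 log units; within the scatter), because the same change gave a 2.0-fold lower number from compound 1 to compound 2 (0.29 log units; within the scatter), a step within the scatter. Compound 4 is therefore estimated at 6000 nM, most likely between 2500 nM and 15000 nM.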

Compound 4, half-maximal inhibitory concentration: 22500 nM
Compound 4: middle estimate off by 3.8-fold (0.57 log units), on the low side, outside the stated range (above it).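

In this assay, 5-chlorothiophen-2-yl in place of 3-methylthiophen-2-yl gave a 2.1-fold higher number from compound 3 to compound 4 (0.33 log units; beyond the scatter), a modest step, and it did not repeat the earlier result on the other core: the same change on two cores in this assay, a 2.0-fold lower number (0.29 log units; within the scatter) from compound 1 to compound 2 and a 2.1-fold higher number (0.33 log units; beyond the scatter) from compound 3 to compound 4, 4.2-fold (0.62 log units) apart, beyond the scatter of two such steps

The effect of this change therefore did not carry from the core of compound 1 to the core of compound 3, so the step on one core is a poor guide to the step on the other in this series. For the compounds shown here, this does not show which feature of the two cores sets the steps apart, whether the 4-chlorophenyl group of compound 1, the 5-chlorofuran-2-yl group of compound 3 or something else, and with only two steps, one of them within the scatter, it gives no general rule for the series.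

The compounds shown leave open how this place would respond to a group of another kind, such as an amine, a carboxylic acid or a longer alkyl chain in place of the thiophene. They also leave open whether the same change would go up or down on any further core.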